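The source may hold more compounds than are shown below. What is called first, only, known or untested is meant among the compounds shown, and "the series" means these compounds.

Measured compounds:
compound 1 `O=C(/C=C/c1cccc(O)c1)c1cc(O)c(O)c([N+](=O)[O-])c1` — 43900 nM
compound 2 `CC(=O)N1N=C(c2cc(O)c(O)c([N+](=O)[O-])c2)CC1c1nccs1` — 84600 nM

Of the compounds shown here, two have been measured in an assay on isolated protein for inhibition of Amine oxidase [flavin-containing] A (Homo sapiens), read by fluorescence; a higher number here means a weaker inhibitor, a lower number a stronger inhibitor. Compound 1 gives 43900 nM in this assay. Compound 2 gives 84600 nM in this assay, the higher of the two numbers, but the gap to compound 1 lies within the usual scatter, so the two cannot be told apart on these numbers.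

Compound 3 `CC(=O)N1N=C(c2cc(O)c(O)c([N+](=O)[O-])c2)CC1c1cccc(C#N)c1` has not yet been measured. It differs from compound 2 in one place: 3-cyanophenyl in place of 1,3-thiazol-2-yl on a saturated ring carbon. Within the data shown here, no step between measured compounds shows what such a change does, so the expectation rests on compound 2 alone and the direction is open. Given that compound 2 gives 84600 nM in this assay, compound 3 is expected to stay close to it, with a step from compound 2 to compound 3 of about a 1.4-fold lower number from compound 2 to compound 3 (0.15 log units; within the scatter), which would not go beyond the scatter. The estimate for compound 3 in this assay is 60000 nM, with a range from 15000 nM to 200000 nM.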

Compound 3, half-maximal inhibitory concentration: 70600 nM
Beside the measured number, compound 3's estimate is 1.2-fold (0.07 log units) below it, within the range that was stated.
By their numbers in this assay, from the lowest: compounds 1, 3 and 2 (each within the scatter of the next).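

In this assay, among these compounds, the exchange of 1,3-thiazol-2-yl for 3-cyanophenyl gives a 1.2-fold lower number from compound 2 to compound 3 (0.08 log units; within the scatter) and is the first step that can be read at this position. On this saturated ring carbon, a six-membered aromatic ring of carbon only, carrying a nitrile, thus stands in place of a five-membered aromatic ring with 2 hetero atoms, and the assay does not tell compound 2 and compound 3 apart. Nothing measured here bears on the reason for this result.

Still open is whether any group at this carbon can carry the number beyond the scatter: the two groups compared are both aromatic rings, and the compounds shown say nothing about an amine, a carboxylic acid or a longer alkyl chain in this place. Also open, as far as these compounds go, is what the nitrile contributes, which a plain phenyl ring would show, and what the acetyl group contributes, which a propanoyl group on that ring atom would show.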